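This account rests on a few compounds, and the source may have more. Where it says the series, first, only, none or still open, it means among the compounds named here.

Measured compounds:
compound 1, `O=C(Cn1nnc(-c2ccccc2)n1)Nc1ccccn1`, in an assay on HEK293 cells for activation of Kir3.1/Kir3.2 (Homo sapiens), read by thallium flux; a lower number here means a smaller maximal response, a higher number a larger maximal response: "not active" (no number reported)
compound 2, `Cc1cc(NC(=O)Cn2nnc(-c3cc(Cl)cc(Cl)c3)n2)n(C2CCCCC2)n1`, in this assay: 82%

Compound 1 is reported in this assay only as "not active" (no number reported), without a number. Compound 2 therefore stands alone: in this assay compound 2 reaches 82%, and no second numerical value exists to set beside it. Compound 3, `Cc1ccc(-c2nnn(CC(=O)Nc3cc(C)nn3C3CCCCC3)n2)cc1`, has not yet been measured. It differs from compound 2 in one place: 4-methylphenyl in place of 3,5-dichlorophenyl on an aromatic carbon.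

Among the measured compounds shown here, no step between measured compounds that differ in one place is available, so the size of the change in this assay from compound 2 to compound 3 cannot be read from earlier pairs. Because compound 2 already reaches 82%, little room remains upward, and a change of this kind on the shared core is as likely to lower the maximal response as to leave it within the usual scatter. The step from compound 2 to compound 3 is expected to be a number 22 percentage points lower from compound 2 to compound 3 (beyond the scatter), downward rather than upward. Compound 3 is expected to give 60% in this assay, estimated to fall within 20% to 95%.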

Compound 3, largest response reached (Emax), in percent of the reference or control that the assay uses: 86%
Compound 3: the middle estimate sits 26 percentage points below what was measured; the range from low to high includes it.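

In this assay, placing 4-methylphenyl instead of 3,5-dichlorophenyl on the aromatic carbon of the five-membered aromatic ring with 4 nitrogen amounts to a number 4 percentage points higher from compound 2 to compound 3 (within the scatter), the first step read at this position. Within these two compounds, the maximal response cannot be told apart whether the six-membered aromatic ring of carbon carries two chlorine atoms or a single methyl group, so the high response of compound 2 does not depend on the chlorine atoms being present, and compound 3 reaches a comparable level without any. No measurement shown accounts for this result, so it stands as an observation without an explanation.

What remains open is how far this tolerance extends, since both groups are phenyl rings bearing no hydrogen-bond donors or acceptors, and the compounds shown do not tell whether an amine, a carboxylic acid or a longer chain such as butyl on that ring would give a similar response. Nor can one step at one position show whether the cyclohexyl group or other parts of the shared core would tolerate exchange as well.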